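A few compounds are considered here, and "the series" means these few. Any claim that something is new, unique, unknown or untested is made for them only; others in the source may bear on it.

In a physicochemical assay for lipophilicity, measured as octanol-water partition, at pH 7.4 (a higher number here means a more lipophilic compound, a lower number a more polar compound), compound 2 `Cc1ccc2[nH]c(C(=O)N[C@H]3CN(S(=O)(=O)c4ccccc4)C[C@@H]3C(=O)NC[C@H]3CCCN3C)cc2c1` gives 2.3. Its closest comparison, compound 1 `Cc1ccc2[nH]c(C(=O)N[C@H]3CN(S(=O)(=O)c4ccccc4)C[C@@H]3C(=O)NC[C@@H]3CCCN3C)cc2c1`, gives 2.3, so the two stand level. Compound 3 `Cc1ccc2[nH]c(C(=O)N[C@H]3CN(S(=O)(=O)c4ccccc4)C[C@@H]3C(=O)N[C@@H]3CCCNC3)cc2c1` keeps the shared core but alters the group on an amide-type nitrogen, with piperidin-3-yl in place of (1-methylpyrrolidin-2-yl)methyl (piperidin-3-yl in place of (1-methylpyrrolidin-2-yl)methyl on an amide-type nitrogen).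

Among the compounds with values here, only one measured step is available, no change at the digits printed from compound 1 to compound 2 (within the scatter), and it offers little guide to the size of this change because of the fact that compounds 1 and 2 differ only in the configuration as drawn. Within the data shown here, no measured pair exchanges the group itself, so the data give no direct calibration for it. The expectation therefore rests on the counted difference in hydrogen-bond donors and heavy atoms, applied to compound 2 at 2.3 in this assay. The new group carries a hydrogen-bond donor that the old one lacks, and this points towards a lower reading, with a wide margin on either side. The estimated change is a number 0.50 log units lower from compound 2 to compound 3 (beyond the scatter), an expected fall that would probably lie beyond the scatter. The estimate for compound 3 is 1.8, with an expected range from 1.2 to 2.4.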

Compound 3, distribution coefficient: 1.3
Compound 3: middle estimate off by 0.50 log units, on the high side; measured number inside the range.
By their numbers in this assay, from the lowest: compound 3; then compounds 1 and 2 (each within the scatter of the next).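

In this assay, the place on the amide-type nitrogen responds to a change of group: piperidin-3-yl in place of (1-methylpyrrolidin-2-yl)methyl gives a number 1.00 log units lower from compound 2 to compound 3 (beyond the scatter), and the same exchange gives a number 1.00 log units lower from compound 1 to compound 3 (beyond the scatter). The earlier pair had shown only that redrawing one stereocentre in the (1-methylpyrrolidin-2-yl)methyl group left the reading level, so this is the first sign that the group itself can move the number beyond the scatter. The two steps are the same size, and they amount to one exchange read from two starting points because of what separates those starting points: the fact that compounds 1 and 2 differ only in the configuration as drawn.

The exchange alters several counted features at once, replacing a five-membered ring with a six-membered one, removing one heavy atom and adding a hydrogen-bond donor, so the compounds shown do not tell which of these goes with the lower reading. A 1-methylpiperidin-3-yl group on the same nitrogen would keep the six-membered ring without the donor, and its reading would begin to separate these features.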